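The compounds below may be only part of what the source reports. "The series", "measured", "known", "first", "only" and "open" are said of these compounds alone.

The measured compounds:
Compound 1 `COC(=O)[C@H](CCSC)NC(=O)c1ccc(NCc2cncn2Cc2ccc(C)cc2)cc1-c1ccccc1` — in a functional assay on NIH3T3 cells (Mus musculus) (a lower number here means that less compound is needed, a higher number that more compound is needed for the effect), compound 1 gives > 10 uM, which is a limit of the assay and not a number.
Compound 2 `CSCC[C@H](NC(=O)c1ccc(NCc2cncn2Cc2ccc(C)cc2)cc1-c1ccccc1)C(=O)O` — in this assay compound 2 gives > 10 uM, again only a limit.
Compound 3 `COC(=O)[C@H](CCSC)NC(=O)c1ccc(CNCc2cncn2Cc2ccc(C#N)cc2)cc1-c1ccccc1C` — in this assay compound 3 gives > 10 uM, also a limit.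

Compound 2 therefore stands at a limit, and every value shown sits at the limit of > 10 uM in this assay, at which 3 of the 3 values shown sit. The single change that can be followed among these compounds, a step that the two limits leave unreadable from compound 1 to compound 2, lies between two limits, so its size cannot be read. Compound 4 `CSCC[C@H](NC(=O)c1ccc(NCc2cncn2Cc2ccccc2C)cc1-c1ccccc1)C(=O)O` differs from compound 2 in one place: 2-methylphenyl in place of 4-methylphenyl on a saturated chain carbon bound to an aromatic nitrogen. For the measured compounds named here, no measured step touches that place, so nothing gives a direction, and the step that the limit leaves unreadable from compound 2 to compound 4 is an estimate with a wide range. Compound 4 is expected to give about 15 uM, between 3 uM and 80 uM.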

Compound 4, concentration for half-maximal effect: > 10 uM
Compound 4 was reported as a limit; the forecaster's own chance of this, stated with the estimate: 75%; the middle value does not contradict the limit.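

Compound 2 and compound 4 both stand at a limit and not at a number, so no size can be read for the step between them: the limit of > 10 uM in this assay, at which 4 of the 4 values shown sit. The compounds shown leave open whether 2-methylphenyl and 4-methylphenyl differ at all in this assay.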